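Swapping a Pyrrolidine for a Pentafluorophenyl on a Carbonyl

A few compounds are considered here, and "the series" means these few. Any claim that something is new, unique, unknown or untested is made for them only; others in the source may bear on it.

Compound 1 `O=C(/C(=C\c1ccc(O)c([N+](=O)[O-])c1)SCc1ccc(Br)cc1)c1c(F)c(F)c(F)c(F)c1F`, compound 2 `O=C(/C(=C\c1ccc([N+](=O)[O-])c(O)c1)SCc1ccc(Br)cc1)C1CCNC1` and compound 3 `O=C(/C(=C\c1ccc(O)c([N+](=O)[O-])c1)SCc1ccc(Br)cc1)C1CCNC1` were examined in a functional assay on DU-145 cells (Homo sapiens) for inhibition, read by trypan blue exclusion, with a stated time of 96 h; a higher number here means a weaker inhibitor of growth, a lower number a stronger inhibitor of growth. Compound 1 gives 10000 nM. For compound 2 the assay reports only a limit, > 100000 nM. For compound 3 likewise only a limit, > 100000 nM, is known. Worth noting is the limit of > 100000 nM in this assay, at which 2 of the 3 values shown sit. Compound 1 differs from compound 3 by 2,3,4,5,6-pentafluorophenyl in place of pyrrolidin-3-yl on a carbonyl carbon, a change that gave an at least 10-fold lower number from compound 3 to compound 1 (1.00 log units; beyond the scatter). Compound 4 `O=C(/C(=C\c1ccc([N+](=O)[O-])c(O)c1)SCc1ccc(Br)cc1)c1c(F)c(F)c(F)c(F)c1F` is not yet measured; it carries the same change relative to compound 2, namely (2,3,4,5,6-pentafluorophenyl in place of pyrrolidin-3-yl on a carbonyl carbon), while how the cores of compound 2 and compound 3 differ is not broken down here. Because the earlier change gave an at least 10-fold lower number from compound 3 to compound 1 (1.00 log units; beyond the scatter), the step from compound 2 to compound 4 in this assay is expected to be an at least 8.3-fold lower number from compound 2 to compound 4 (0.92 log units; beyond the scatter). Compound 4 is therefore estimated at 12000 nM, probably between 3000 nM and 60000 nM.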

Compound 4, concentration for 50% growth inhibition: 10000 nM
The estimate for compound 4 lay 1.2-fold (0.08 log units) above the measured number; measured number inside the range.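

In this assay, putting 2,3,4,5,6-pentafluorophenyl in place of pyrrolidin-3-yl on the carbonyl carbon carried over to a second core and gave an at least 10-fold lower number from compound 2 to compound 4 (1.00 log units; beyond the scatter). Set beside the first case, the change looks similar on both cores, but the comparison has an open end: the same change on two cores in this assay, an at least 10-fold lower number (1.00 log units; beyond the scatter) from compound 3 to compound 1 and an at least 10-fold lower number (1.00 log units; beyond the scatter) from compound 2 to compound 4; the limit leaves it open whether they differ. From the compounds shown here alone, the true size of either step stays unknown, since each starting compound is only a limit and not a number: the limit of > 100000 nM in this assay, at which 2 of the 4 values shown sit.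

Between the two pentafluorophenyl compounds, moving from 4-hydroxy-3-nitrophenyl to 3-hydroxy-4-nitrophenyl gives no change at the digits printed from compound 1 to compound 4 (within the scatter). Going by these compounds, whether an unsubstituted phenyl or an open-chain amine on the carbonyl carbon would behave like either group remains open.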